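The source may report more compounds than this note shows. Statements on the series, on what has been measured and on what is new or still open speak of the compounds shown alone.

Compound 2, whose structure is `Cc1c(C=O)cc(-c2ccc(S(C)(=O)=O)cc2)n1-c1ccc(F)c(F)c1`, is set against compound 1, whose structure is `Cc1c(C=O)cc(-c2ccc(S(C)(=O)=O)cc2)n1-c1cccc(F)c1`. In a functional assay on the whole organism (strain Swiss albino) for inhibition, with Mus musculus as the target, in the writhing test, with a stated time of 30 min, at a dose of 20 mg/kg by the oral route (a higher number here means a stronger effect of the compound at the dose given, a lower number a weaker effect), compound 2 gives 52%. In this assay compound 1 gives 44%. Among the compounds with values here, the one measured step, a number 8 percentage points higher from compound 1 to compound 2 (within the scatter), is therefore the only guide to what a change on the aromatic ring attached to the nitrogen does here, and that step stays within the scatter, so the two compounds stand together rather than in any order.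

Compound 3, whose structure is `Cc1c(C=O)cc(-c2ccc(S(C)(=O)=O)cc2)n1-c1ccccc1`, has not yet been measured. It differs from compound 2 by phenyl in place of 3,4-difluorophenyl on an aromatic nitrogen. This change runs against the direction of the measured step and goes further than it, since both fluorines leave. Because a number 8 percentage points higher from compound 1 to compound 2 (within the scatter) did not rise beyond the scatter when one fluorine entered, the removal of two is expected to give at most a modest fall in this assay, and quite possibly no change beyond the scatter. Compound 3 is accordingly expected to give about 40%, within a range from 25% to 56%, which amounts to an expected step of a number 12 percentage points lower from compound 2 to compound 3 (beyond the scatter).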

Compound 3, a percentage reported as inhibition, in the whole organism at one dose (the size of the read-out at that dose, not a potency): 32%
For compound 3 the middle estimate is 8 percentage points above the measured one; the range from low to high includes it.
By their numbers in this assay, from the lowest: compound 3; then compounds 1 and 2 (each within the scatter of the next).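

Taken together, the compounds show that the aromatic group on the nitrogen does matter in this assay: going from 3,4-difluorophenyl to phenyl gives a number 20 percentage points lower from compound 2 to compound 3 (beyond the scatter), the first step at this position to pass beyond the scatter. Within the data shown here, removing the single fluorine gives a number 12 percentage points lower from compound 1 to compound 3 (beyond the scatter), so the unsubstituted phenyl falls beyond the scatter from both fluorinated compounds, while compound 1 and compound 2 still stand together, and having at least one fluorine on this ring, rather than a second one, is what separates the three compounds. No measured information shown here accounts for this difference.

On these data alone, whether chloro, methoxy or an amine on this ring would match fluoro, or would stay with the bare phenyl, remains open, as does whether a carboxylic acid or a longer chain in place of the formyl group would alter the effect of the fluorines. These read-outs also come from a single dose, so they speak only of a stronger or weaker effect at that dose.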